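Benzyloxy to benzylsulfanyl exchange on the shared core

The compounds below may be only part of what the source reports. "The series", "measured", "known", "first", "only" and "open" are said of these compounds alone.

Compound 2 `CC(C(=O)NCc1ccc(C(F)(F)F)cc1OCc1ccc(F)cc1)c1ccc(NS(C)(=O)=O)c(F)c1` holds the lowest number of the two measured in an assay on CHO cells for antagonist activity at transient receptor potential cation channel subfamily V member 1 (Homo sapiens), read by FLIPR (a higher number here means a weaker inhibitor, a lower number a stronger inhibitor), where compound 2 gives 0.5 nM. Its nearest neighbour is compound 1 `CC(C(=O)NCc1ccc(C(F)(F)F)cc1N1CCCC1)c1ccc(NS(C)(=O)=O)c(F)c1`, which in this assay gives 2.3 nM; the step of a 4.6-fold lower number from compound 1 to compound 2 (0.66 log units; beyond the scatter) separates them. Compound 3 `COc1ccc(CSc2cc(C(F)(F)F)ccc2CNC(=O)C(C)c2ccc(NS(C)(=O)=O)c(F)c2)cc1` differs from compound 2 by (4-methoxybenzyl)sulfanyl in place of (4-fluorobenzyl)oxy on an aromatic carbon, placed on an aromatic carbon of a six-membered aromatic ring of carbon only, ortho to a large group and meta to a trifluoromethyl group. For the measured compounds named here, no measured step exchanges an ether oxygen for a sulfur or a fluorine for a methoxy group; the only step, from pyrrolidin-1-yl to (4-fluorobenzyl)oxy, concerns a different change and gives no direction for this one. A step near the scatter, in either direction, is therefore expected, as a 2.0-fold higher number from compound 2 to compound 3 (0.30 log units; within the scatter). Compound 3 is estimated at 1 nM, with a range from 0.3 nM to 4 nM.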

Compound 3, inhibition constant: 2.3 nM
Estimate against measurement, compound 3: 2.3-fold (0.36 log units) below; the range from low to high includes it.
By their numbers in this assay, from the lowest: compound 2; then compounds 1 and 3 (each within the scatter of the next).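

In this assay, the exchange of (4-fluorobenzyl)oxy for (4-methoxybenzyl)sulfanyl on this aromatic carbon gives a 4.6-fold higher number from compound 2 to compound 3 (0.66 log units; beyond the scatter), so the position distinguishes between two substituents that each carry a six-membered aromatic ring of carbon only. The second step reads no change at the digits printed from compound 1 to compound 3 (within the scatter), so such a ring does not by itself give the low number of compound 2: compound 3 carries one and stands level with the pyrrolidin-1-yl of compound 1. Nothing at hand bears on the cause of either step.

The sulfur and the methoxy group enter in the same step, leaving their separate shares open; (4-fluorobenzyl)sulfanyl and (4-methoxybenzyl)oxy would divide them. Also open, as far as these compounds go, is how an unsubstituted benzyloxy group or a longer phenethyloxy chain would read at this carbon.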